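The source may hold more compounds than are shown below. What is called first, only, known or untested is meant among the compounds shown, and "the series" means these compounds.

Compound 1 `COc1cccc(/C=C/C(=O)c2ccccc2O)c1` and compound 2 `O=C(/C=C/c1cccc(Br)c1)c1ccccc1O` share one core and differ in a single place. In a functional assay on HCT-116 cells (Homo sapiens) for cytotoxicity, read by MTT assay, with a stated time of 48 h, tested at 15 uM (a lower number here means a stronger effect, a higher number a weaker effect of the compound at the concentration tested), compound 1 gives 89.6%, while compound 2 gives 29.6%, so compound 2 stands lowest of the two numbers, with a number 60 percentage points lower from compound 1 to compound 2 (beyond the scatter). Compound 3 `O=C(/C=C/c1cccc(Cl)c1)c1ccccc1O` carries chloro in place of bromo on an aromatic carbon. For the measured compounds named here, no measured step exchanges one halogen for another; the only step known, bromo for methoxy, was large. Since a chloro-for-bromo exchange is a smaller alteration, compound 3 is expected to stay close to its predecessor, an estimate of 40% with a range from 22% to 62%, meaning a number 10.4 percentage points higher from compound 2 to compound 3 (beyond the scatter).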

Compound 3, a percentage reported as activity, at one concentration (the size of the read-out at that concentration, not a potency): 37.5%
Compound 3: the middle estimate sits 2.5 percentage points above what was measured, within the range that was stated.
By their numbers in this assay, from the lowest: compounds 2 and 3 (each within the scatter of the next); then compound 1.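

In this assay, exchanging bromo for chloro on this aromatic carbon leaves the read-out within the usual scatter (a number 7.9 percentage points higher from compound 2 to compound 3 (within the scatter)). Chloro in place of methoxy gives a large step (a number 52.1 percentage points lower from compound 1 to compound 3 (beyond the scatter)), so the strong step seen with bromo is not confined to that one halogen. Nothing available explains the gap between these halogens and methoxy. Open, from the compounds shown here alone, is how fluoro, an amine or a carboxylic acid would read at this place, and whether these halogens would give similar numbers elsewhere on the ring.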